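A few compounds are considered here, and "the series" means these few. Any claim that something is new, unique, unknown or untested is made for them only; others in the source may bear on it.

Measured so far:
Compound 1 `CC(=O)c1ccc(NC(=O)Cn2nc(-c3ccc(Cl)cc3)nc2N)cc1` gives 15.4%
Compound 2 `C/C(=N\O)c1ccc(NC(=O)Cn2nc(-c3ccc(Cl)cc3)nc2N)cc1` gives 18%
Compound 3 `COc1cc(-c2nc(N)n(CC(=O)Nc3ccc(/C(C)=N\O)cc3)n2)cc(OC)c1OC` gives 25.7%

These three numbers come from a functional assay on OVCAR-8 cells (Homo sapiens) for inhibition, read by sulforhodamine B assay, with a stated time of 48 h, tested at 10 uM (a lower number here means less inhibition of growth, a higher number more inhibition of growth at the concentration tested), and all sit well short of full inhibition. Compound 1 lies at the low end of the set, at 15.4%, within the scatter of compound 2, whereas compound 3 stands higher than compound 1 by more than the scatter.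

The unmeasured compound 4 `CC(=O)c1ccc(NC(=O)Cn2nc(C(F)(F)F)nc2N)cc1` keeps the rest of compound 1 but carries trifluoromethyl in place of 4-chlorophenyl on an aromatic carbon. For the measured compounds named here, the only measured single-place step is a number 2.6 percentage points higher from compound 1 to compound 2 (within the scatter), and it concerns a different place, so it shows a small move but says nothing direct about this one. Going by the values given here, no measured compound lacks a ring at the carbon that changes, so the data hold no direct precedent for the swap.

With so little to go on, a modest fall is expected rather than a clear one, and the expected size stays within the scatter. The expected step is a number 3.4 percentage points lower from compound 1 to compound 4 (within the scatter) in this estimate. For compound 4 the estimated value is 12%, with an expected range from 2% to 25%.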

Compound 4, percent growth inhibition at one concentration: 13.3%
Estimate against measurement, compound 4: 1.3 percentage points below; measured number inside the range.
By their numbers in this assay, from the lowest: compounds 4, 1, 2 and 3 (each within the scatter of the next, the first and the last beyond it).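

In this assay, trifluoromethyl in place of 4-chlorophenyl on this aromatic carbon gives a number 2.1 percentage points lower from compound 1 to compound 4 (within the scatter), so the read-out does not separate the two compounds. Compound 4 is the first compound shown with no ring at this carbon, and it shows that, on the core of compound 1, a group of 4 heavy atoms without a ring can stand in place of a six-membered aromatic ring and its chlorine with no change beyond the scatter, which the earlier compounds, all ring-bearing here, could not show. Nothing measured on these compounds offers an explanation for this result.

Since compound 1 and compound 4 both leave most growth uninhibited at the concentration tested, the step says little about whether this carbon matters for stronger inhibition, or whether trifluoromethyl would behave the same way on the core of compound 2 or compound 3. As far as these compounds go, it also remains open how an amine, a carboxylic acid or a longer alkyl chain would read out at this carbon.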